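The source may hold more compounds than are shown below. What is called first, only, known or untested is meant among the compounds shown, and "the series" means these compounds.

Of the compounds shown here, three built on one shared core have been measured in a functional assay on the whole organism (strain Wistar) with Rattus norvegicus as the target, with a stated time of 15 days, at a dose of 30 mg/kg by the oral route; a higher number here means a stronger effect of the compound at the dose given, a lower number a weaker effect. Compound 1 `O=C1NC(=O)/C(=C/c2ccc(OCCSc3nnc(-c4ccccc4)[nH]3)cc2)S1` gives 26.4%. Compound 2 `O=C1NC(=O)/C(=C/c2ccc(OCCSc3nnc(Cc4ccccc4)[nH]3)cc2)S1` gives 38.3%, and compound 3 `Cc1ccc(-c2nnc(SCCOc3ccc(/C=C4\SC(=O)NC4=O)cc3)[nH]2)cc1` gives 40.3%. Compound 3 and compound 2 lie within the scatter of each other, so neither can be ranked above the other, while both stand clearly above compound 1, as the steps of a number 11.9 percentage points higher from compound 1 to compound 2 (beyond the scatter) and a number 13.9 percentage points higher from compound 1 to compound 3 (beyond the scatter) show; the step of a number 2 percentage points higher from compound 2 to compound 3 (within the scatter) is within the scatter.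

Compound 4 `O=C1NC(=O)/C(=C/c2ccc(OCCSc3nnc(-c4ccc([N+](=O)[O-])cc4)[nH]3)cc2)S1` differs from compound 3 by nitro in place of methyl on an aromatic carbon. For the measured compounds named here, the only measured step that touches this same aromatic carbon is a number 13.9 percentage points higher from compound 1 to compound 3 (beyond the scatter), a modest gain. The other two steps change a different part of the molecule and say little here. Going by the values given here, no measured compound carries a nitro group, so the direction of this change is not backed by any number; a small step, not beyond the scatter, is expected, a number 5.3 percentage points lower from compound 3 to compound 4 (within the scatter). For compound 4 in this assay the estimated value is 35%, with a range from 20% to 50%.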

Compound 4, a percentage reported as activity, at one dose (the size of the read-out at that dose, not a potency): 18.6%
Estimate against measurement, compound 4: 16.4 percentage points above, and the stated range ends above it.
By their numbers in this assay, from the lowest: compounds 4 and 1 (each within the scatter of the next); then compounds 2 and 3 (each within the scatter of the next).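

The carbon para to a large group in this assay does not reward any added group: nitro in place of methyl gives a number 21.7 percentage points lower from compound 3 to compound 4 (beyond the scatter) and so loses what methyl had gained, while 4-nitrophenyl in place of benzyl gives a number 19.7 percentage points lower from compound 2 to compound 4 (beyond the scatter) and falls well short of the other substituted compound as well. Nitro in place of hydrogen gives a number 7.8 percentage points lower from compound 1 to compound 4 (within the scatter) and so leaves the unsubstituted phenyl compound and its nitro counterpart unranked, which means the group does not push the read-out clearly under that of the parent. No measured property of these groups is available to account for the contrast between methyl and nitro. On these data alone, what an amino group, a methoxy group or a chlorine atom would give on this same carbon stays open. So does whether a nitro group on the benzyl ring of compound 2 would take the same step.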